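Pyrrolidin-1-yl in place of (3-methoxyphenyl)amino

A few compounds are considered here, and "the series" means these few. Any claim that something is new, unique, unknown or untested is made for them only; others in the source may bear on it.

Among the measured compounds shown here, in a functional assay on MCF7 cells (Homo sapiens) for inhibition, read by sulforhodamine B assay (on this read-out higher numbers stand for weaker inhibition and lower numbers for stronger inhibition), no compound yet has a number, only limits. Compound 1 `O=C1C=C(NC2CCCCC2)C(=O)c2c1nc1n2[C@H]2OC[C@@H](O)[C@H]2OC1` gives > 8000 nM, which is a limit. Compound 2 `CCCN(CCC)C1=CC(=O)c2nc3n(c2C1=O)[C@H]1OC[C@@H](O)[C@H]1OC3` gives > 16000 nM, also a limit. From the compounds shown here alone, compound 3 `COc1cccc(NC2=CC(=O)c3nc4n(c3C2=O)[C@H]2OC[C@@H](O)[C@H]2OC4)c1` gives > 4000 nM, again a limit, so its place on the scale stays open.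

Compound 4 `O=C1C=C(N2CCCC2)C(=O)c2c1nc1n2[C@H]2OC[C@@H](O)[C@H]2OC1` differs from compound 3 as follows: pyrrolidin-1-yl in place of (3-methoxyphenyl)amino on a double-bonded ring carbon. The measured steps that bear on this change are a step that the two limits leave unreadable from compound 1 to compound 3 and a step that the two limits leave unreadable from compound 2 to compound 3, so neither offers a size to carry over. Nothing in these data points to a gain in this assay. The expected step is a step that the limit leaves unreadable from compound 3 to compound 4, an estimate resting on limits alone. For compound 4 the estimated value is 12000 nM, with an expected range of 4000 nM to 40000 nM.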

Compound 4, half-maximal inhibitory concentration: > 16000 nM
Compound 4 was reported as a limit (the forecaster's own chance of this, stated with the estimate: 75%); at least 1.3-fold (0.12 log units) between middle value and limit.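

Among the compounds shown here, compound 4 is reported only as a limit, as are compound 1, compound 2 and compound 3, so no step to compound 4 can be read in this assay. The compounds shown leave open where any of them stands on the scale, and whether the amino groups differ at all.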